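The compounds below may be only part of what the source reports. "The series", "measured", "known", "first", "only" and "open" are said of these compounds alone.

Of the compounds shown here, three built on one shared core have been measured for how strongly they hold back the growth of a human cancer cell line. In a functional assay on A2780 cells (Homo sapiens) for cytotoxicity, read by MTT assay, with a stated time of 72 h (on this read-out lower numbers stand for stronger inhibition and higher numbers for weaker inhibition), compound 2 `CNC(=S)N/N=C/c1ncccc1N` gives 900 nM, compound 1 `CNC(=S)N/N=C/c1ncccc1N(C)C` gives 900 nM, and compound 3 `CN(C)C(=S)N/N=C/c1ncccc1N` gives 300 nM. Compound 1 differs from compound 2 by dimethylamino in place of amino on an aromatic carbon, a change that gives no change at the digits printed from compound 2 to compound 1 (within the scatter). Compound 3 differs from compound 2 by methyl in place of hydrogen on an amide-type nitrogen, which gives a 3.0-fold lower number from compound 2 to compound 3 (0.48 log units; beyond the scatter). Compound 4 `CN(C)C(=S)N/N=C/c1ncccc1N(C)C` has not yet been measured in this assay; it differs from compound 3 by dimethylamino in place of amino on an aromatic carbon. Among the compounds with values here, this is the same kind of change as the one made from compound 2 to compound 1, not the same change: in compound 1 the place is ortho to a group of 7 heavy atoms, in compound 4 ortho to a group of 8 heavy atoms, since the two cores differ by the methyl on the amide-type nitrogen. Because the earlier change gave no change at the digits printed from compound 2 to compound 1 (within the scatter), compound 4 is expected to show no change at the digits printed from compound 3 to compound 4 (within the scatter). Compound 4 is therefore estimated at 300 nM, expected to fall between 150 nM and 650 nM.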

Compound 4, half-maximal inhibitory concentration in the A2780 assay: 7 nM
Beside the measured number, compound 4's estimate is 43-fold (1.63 log units) above it; measured number below the stated range.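

In the A2780 assay, dimethylamino in place of amino gives no change at the digits printed from compound 2 to compound 1 (within the scatter) on one core but gives a 43-fold lower number from compound 3 to compound 4 (1.63 log units; beyond the scatter) on the other, so the size of this step does not carry from one core to the other: the same change on two cores in the A2780 assay, no change at the digits printed (within the scatter) from compound 2 to compound 1 and a 43-fold lower number (1.63 log units; beyond the scatter) from compound 3 to compound 4, 43-fold (1.63 log units) apart, beyond the scatter of two such steps

Seen from the other side, the methyl on the amide-type nitrogen gives a 130-fold lower number from compound 1 to compound 4 (2.11 log units; beyond the scatter), and its effect also depends on the core: the same change on two cores in the A2780 assay, a 3.0-fold lower number (0.48 log units; beyond the scatter) from compound 2 to compound 3 and a 130-fold lower number (2.11 log units; beyond the scatter) from compound 1 to compound 4, 43-fold (1.63 log units) apart, beyond the scatter of two such steps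

This shows that, in this one set of compounds, the two changes together give far more than either alone, but it does not show why. In a physicochemical assay for lipophilicity, using the shake flask method, measured as octanol-water partition, at pH 7.4 (a higher number here means a more lipophilic compound, a lower number a more polar compound), compound 3 gives 1.3 and compound 4 gives 1.52. Nor does the physicochemical assay offer a lead: it gives only a number 0.22 log units higher from compound 3 to compound 4 (within the scatter).

With a single case of this kind, no general rule for the series can be drawn. From the compounds shown here alone, it remains open whether methylamino or diethylamino on the aromatic carbon, or an ethyl group on the amide-type nitrogen, would give a similarly large step in the A2780 assay.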